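Aromatic substituent swaps on a piperidine bis-amide series

A few compounds are considered here, and "the series" means these few. Any claim that something is new, unique, unknown or untested is made for them only; others in the source may bear on it.

Measured so far:
Compound 1, `O=C(Nc1cccc(Oc2nccc(C(F)(F)F)c2Cl)c1)C1CCCN(C(=O)c2cc(C(F)(F)F)cc(C(F)(F)F)c2)C1`: 0%
Compound 2, `O=C(Nc1cccc(-c2cnco2)c1)C1CCCN(C(=O)c2cc(C(F)(F)F)cc(C(F)(F)F)c2)C1`: 9%
Compound 3, `Cc1nc(-c2cccc(C(=O)N3CCCC(C(=O)Nc4ccc(Cl)cc4)C3)c2)no1`: 0%

In an ADME assay on PC-3 cells (Homo sapiens) for cytotoxicity, read by WST assay, tested at 100 uM (a lower number here means less inhibition, a higher number more inhibition at the concentration tested (going by the name of the read-out)), compound 1 gives 0% and compound 2 gives 9%. Compound 3 differs from the other two in several positions; in this assay compound 3 gives 0%. The three numbers lie within the scatter of one another, so compound 2 is not separated from compound 1 or from compound 3 on these data; the series as a whole sits at the low end of the read-out.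

The step now under study goes from compound 2 to compound 4, `O=C(Nc1cccc(N2CCCC2=O)c1)C1CCCN(C(=O)c2cc(C(F)(F)F)cc(C(F)(F)F)c2)C1`. The change is 2-oxopyrrolidin-1-yl in place of 1,3-oxazol-5-yl on an aromatic carbon. Among the compounds with values here, one measured step bears on it, since it also exchanges the group on the same aromatic carbon of the shared core: a number 9 percentage points higher from compound 1 to compound 2 (within the scatter). Within the data shown here, that exchange, between two quite different groups, left the read-out within the scatter, and no measured compound in this set moves off the floor of this assay. For the change from compound 2 to compound 4 no step beyond the scatter is therefore expected, in either direction.

Compound 4 is expected to give 5% in this assay, within 0% to 15%, a change of a number 4 percentage points lower from compound 2 to compound 4 (within the scatter) that is estimated to stay within the scatter.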

Compound 4, a percentage reported as inhibition, at one concentration (the size of the read-out at that concentration, not a potency): 0%
The estimate for compound 4 lay 5 percentage points above the measured number; the measured number falls inside the stated range.
By their numbers in this assay, from the lowest: compounds 1, 3, 4 and 2 (each within the scatter of the next).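

This step adds a non-aromatic ring to the groups read at this aromatic carbon: 2-oxopyrrolidin-1-yl replaces the five-membered aromatic 1,3-oxazol-5-yl in this assay (a number 9 percentage points lower from compound 2 to compound 4 (within the scatter)), and it also replaces the (3-chloro-4-(trifluoromethyl)pyridin-2-yl)oxy group (no change at the digits printed from compound 1 to compound 4 (within the scatter)). All three steps among compound 1, compound 2 and compound 4 now lie within the scatter, so on the shared core this position has taken an oxygen-linked pyridine, an aromatic five-membered ring and a non-aromatic five-membered ring without any of them separating from the others in this read-out. No supporting measurement is available to explain why the read-out stays unseparated across these groups.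

From the compounds shown here alone, whether a basic amine or a carboxylic acid on the same aromatic carbon, or a longer chain carrying either, would move the read-out clear of the scatter stays open. With all of these numbers at the low end of the read-out, the data also leave open whether this position can influence this assay at all on this core, and compound 3, which differs in several places, cannot settle that.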